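The source may hold more compounds than are shown below. What is called first, only, known or untested is meant among the compounds shown, and "the series" means these compounds.

Of the compounds shown here, three built on a shared core have so far been tested in a functional assay on MCF7 cells (Homo sapiens) for cytotoxicity, read by sulforhodamine B assay, with a stated time of 72 h; a higher number here means a weaker inhibitor, a lower number a stronger inhibitor. Compound 1 `O=c1c(CNc2ccc(S(=O)(=O)Nc3ccccn3)cc2)coc2ccccc12` gives only a limit in this assay, > 100000 nM, and that limit is described as the limit of > 100000 nM in this assay, at which 1 of the 3 values shown sits. Compound 3 `Cc1cc(C)nc(NS(=O)(=O)c2ccc(NCc3coc4ccccc4c3=O)cc2)n1` gives 93600 nM in this assay. Compound 2 `NS(=O)(=O)c1ccc(NC2=NC(=O)/C(=C\c3coc4ccccc4c3=O)S2)cc1` gives 8910 nM in this assay, the lowest of the two numbers shown, with compound 3 standing well above it, beyond the usual scatter.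

For the measured compounds named here, only one measured step touches the sulfonamide nitrogen: the change from pyridin-2-yl to 4,6-dimethylpyrimidin-2-yl gives an at least 1.0-fold lower number from compound 1 to compound 3 (0.02 log units; that floor lies within the scatter), a step within the scatter, and one of its ends is a limit rather than a number.

Compound 4 `O=C1N=C(Nc2ccc(S(=O)(=O)Nc3nccs3)cc2)S/C1=C/c1coc2ccccc2c1=O` differs from compound 2 by 1,3-thiazol-2-yl in place of hydrogen on a sulfonamide nitrogen. Going by the values given here, no measured pair swaps a hydrogen for a heteroaryl on that nitrogen; the one step there, between two heteroaryls, moved nothing beyond the scatter. Compound 4 is therefore expected to move little, a 1.1-fold higher number from compound 2 to compound 4 (0.05 log units; within the scatter). Compound 4 is estimated at 10000 nM, between 3000 nM and 35000 nM.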

Compound 4, half-maximal inhibitory concentration: > 100000 nM
Compound 4 gave a limit, no number (the forecaster's own chance of this, stated with the estimate: 15%); middle value at least 10-fold (1.00 log units) away from the limit.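

For the compounds shown here, replacing hydrogen with 1,3-thiazol-2-yl on the sulfonamide nitrogen gives an at least 11-fold higher number from compound 2 to compound 4 (1.05 log units; beyond the scatter), so this position does respond in this assay, whereas the one earlier step there, between two heteroaryl groups, stayed within the scatter. Compound 4 gives a limit and no number: the limit of > 100000 nM in this assay, at which 2 of the 4 values shown sit. Within this pair, only compound 2, with the unsubstituted sulfamoyl, gives a number, and this reading rests on that single pair.

The compounds shown leave open whether the change belongs to 1,3-thiazol-2-yl itself or would follow any group on that nitrogen, such as a methyl or an acetyl. On these data alone, the full size of the step also stays open, since one of its ends is a limit and the step therefore has only a floor.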